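A few compounds are considered here, and "the series" means these few. Any claim that something is new, unique, unknown or untested is made for them only; others in the source may bear on it.

In a functional assay on NCI-H322M cells (Homo sapiens) for inhibition, read by sulforhodamine B assay, with a stated time of 48 h, tested at 10 uM (on this read-out higher numbers stand for a weaker effect at the one concentration tested and lower numbers for a stronger effect), compound 2, whose structure is `COc1cc(Cl)cc(-c2nn(-c3cccc(NC(=O)Nc4cccc(C(F)(F)F)c4)c3)cc2-c2ccncc2)c1`, gives 26.2%. Compound 1, with the structure `COc1cc(Cl)cc(-c2nn(-c3cccc(NC(=O)Nc4ccc(Cl)c(Cl)c4)c3)cc2-c2ccncc2)c1`, gives 32.3% in this assay . Within the data shown here, compound 2 holds the lower of the two numbers, but the one step measured so far, a number 6.1 percentage points lower from compound 1 to compound 2 (within the scatter), lies within the scatter, so the two compounds cannot be told apart on these numbers.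

Compound 3 has the structure `COc1cc(Cl)cc(-c2nn(-c3cccc(NC(=O)c4cccc(C(F)(F)F)c4)c3)cc2-c2ccncc2)c1`. It differs from compound 2 by 3-(trifluoromethyl)phenyl in place of (3-(trifluoromethyl)phenyl)amino on a carbonyl carbon, so the linker that joins the two aryl parts loses its second nitrogen-bearing arm and becomes a plain amide.

Among the measured compounds shown here, no measured step touches this part of the molecule: the single step from compound 1 to compound 2 changed only the aryl group on the far nitrogen, and it stayed within the scatter. There is therefore no basis for expecting a step in this assay in either direction beyond the scatter, and the estimate must carry a wide range.

Compound 3 is expected to give about 30%, between 10% and 55%, an estimated step of a number 3.8 percentage points higher from compound 2 to compound 3 (within the scatter).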

Compound 3, a percentage reported as activity, at one concentration (the size of the read-out at that concentration, not a potency): 78.6%
The estimate for compound 3 lay 48.6 percentage points below the measured number, outside the stated range (above it).
By their numbers in this assay, from the lowest: compounds 2 and 1 (each within the scatter of the next); then compound 3.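

Among these compounds, at this position, on a carbonyl carbon whose other neighbour is an amide-type nitrogen, the earlier compounds offered no information, and the result shows that the amino nitrogen linking the aryl group to the carbonyl carbon cannot be removed without a large loss in this assay: a number 52.4 percentage points higher from compound 2 to compound 3 (beyond the scatter), so the effect at the one concentration tested becomes much weaker. The comparison with the dichlorinated urea points the same way, a number 46.3 percentage points higher from compound 1 to compound 3 (beyond the scatter), whereas swapping the aryl group while keeping the amino nitrogen gave only a step within the scatter, so in these three compounds the amino nitrogen counts for far more than the choice of aryl group. Nothing measured here explains why the loss is so large.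

The compounds shown cannot separate the role of the amino hydrogen from that of the nitrogen atom itself, a question that a methylamino group, an oxygen or a methylene on the carbonyl carbon could address. Going by these compounds, it also remains open whether the plain amide would behave the same way with the 3,4-dichlorophenyl group in place of 3-(trifluoromethyl)phenyl.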